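The source may report more compounds than this note shows. Statements on the series, on what has been measured and on what is new or still open speak of the compounds shown alone.

The compounds share one core and differ only in the aromatic ring that sits on a saturated chain carbon bound to a sulfur. Compound 1 `Clc1ccccc1CSc1nnc(-c2ccc3c(c2)OCCO3)o1` carries a 2-chlorophenyl there; in a functional assay on HepG2 cells (Homo sapiens) for antiproliferative activity, read by MTT assay, with a stated time of 48 h (on this read-out higher numbers stand for weaker inhibition and lower numbers for stronger inhibition), compound 1 gives 22600 nM. Compound 3 `Fc1ccccc1CSc1nnc(-c2ccc3c(c2)OCCO3)o1` carries a 2-fluorophenyl, and in this assay compound 3 gives 24000 nM. Compound 2 `Cc1ccc(CSc2nnc(-c3ccc4c(c3)OCCO4)o2)cc1` carries a 4-methylphenyl; in this assay compound 2 gives 41900 nM, the highest of the three numbers, yet both of its steps stay within the scatter: a 1.9-fold higher number from compound 1 to compound 2 (0.27 log units; within the scatter) and a 1.7-fold lower number from compound 2 to compound 3 (0.24 log units; within the scatter). Compound 4 `O=[N+]([O-])c1ccc(CSc2nnc(-c3ccc4c(c3)OCCO4)o2)cc1` is the one not yet measured. It differs from compound 2 in a single place: nitro in place of methyl on an aromatic carbon. Going by the values given here, no measured step swaps a methyl for a nitro, so the only guidance is indirect: every change tried on this ring so far, whether a 1.1-fold higher number from compound 1 to compound 3 (0.03 log units; within the scatter) or the two steps that involve compound 2, left the number inside the scatter. On that basis the step of a 1.2-fold lower number from compound 2 to compound 4 (0.08 log units; within the scatter) is expected to be small, with no clear direction. Compound 4 is therefore estimated at 35000 nM in this assay, with a range from 15000 nM to 80000 nM.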

Compound 4, half-maximal inhibitory concentration: 35400 nM
For compound 4 the middle estimate is 1.0-fold (0.00 log units) below the measured one; measured number inside the range.
By their numbers in this assay, from the lowest: compounds 1, 3, 4 and 2 (each within the scatter of the next).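

In this assay the swap of methyl for nitro (a 1.2-fold lower number from compound 2 to compound 4 (0.07 log units; within the scatter)) shows that this aromatic carbon, para to a large group, accepts 3 heavy atoms in place of 1 and 2 hydrogen-bond acceptors in place of 0 without the number leaving the scatter. Among the earlier steps, only fluoro in place of chloro changed a single group on the ring, whereas this change also brings in a double bond outside aromatic rings. Across the steps between these compounds that differ in one place, no swap has moved the number beyond the scatter, and nothing measured here offers an explanation for the close numbers of compound 2 and compound 4.

The compounds shown leave open whether an amine or a carboxylic acid on this same aromatic carbon, or a longer chain in place of the saturated chain carbon bound to the sulfur, would carry the number beyond the scatter. They also leave open what a change to the shared core would do, since all four compounds carry it unchanged.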